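The compounds below may be only part of what the source reports. "The series", "measured", "known", "first", "only" and "open" are said of these compounds alone.

Three compounds have been measured in a functional assay on SK-MEL-2 cells (Homo sapiens) for inhibition, read by sulforhodamine B assay, with a stated time of 48 h; on this read-out lower numbers stand for stronger inhibition of growth and higher numbers for weaker inhibition of growth:
compound 1, `COc1cc(-c2nn(-c3cccc(NC(=O)Nc4cc(C(F)(F)F)cc(C(F)(F)F)c4)c3)cc2-c2ccncc2)ccc1Cl`, 1020 nM;
compound 2, `O=C(Nc1cccc(-n2cc(-c3ccncc3)c(-c3ccc(Cl)c(O)c3)n2)c1)Nc1cc(C(F)(F)F)cc(C(F)(F)F)c1`, 1250 nM;
compound 3, `COc1cc(-c2nn(-c3cccc(NC(=O)Nc4ccc(Cl)c(C(F)(F)F)c4)c3)cc2-c2ccncc2)ccc1Cl`, 1010 nM.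

Compound 2 comes from compound 1 by a single change, (hydrogen in place of methyl on an oxygen on an aromatic ring). In this assay that change produced a 1.2-fold higher number from compound 1 to compound 2 (0.09 log units; within the scatter), so the two numbers sit inside the ordinary spread of the measurement, and nothing can be said about which of the two is the stronger growth inhibitor. Compound 3 and compound 1 differ in a different part of the molecule; the difference between the two cores is not broken down here, and their numbers in this assay lie within the scatter of each other.

Compound 4, `O=C(Nc1cccc(-n2cc(-c3ccncc3)c(-c3ccc(Cl)c(O)c3)n2)c1)Nc1ccc(Cl)c(C(F)(F)F)c1`, has not yet been measured. It stands to compound 3 as compound 2 stands to compound 1: the change is hydrogen in place of methyl on an oxygen on an aromatic ring, at a place described in exactly the same words in both pairs, so it is the same change made on the core of compound 3. Because the earlier step was a 1.2-fold higher number from compound 1 to compound 2 (0.09 log units; within the scatter), the step from compound 3 to compound 4 is expected to be of similar size, a 1.2-fold higher number from compound 3 to compound 4 (0.07 log units; within the scatter). On that basis compound 4 is estimated to give 1200 nM in this assay, with the likely range running from 650 nM to 2300 nM.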

Compound 4, concentration for 50% growth inhibition: 798 nM
Estimate against measurement, compound 4: 1.5-fold (0.18 log units) above, within the range that was stated.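

Replacing methoxy with hydroxy on the core of compound 3 gave, in this assay, a 1.3-fold lower number from compound 3 to compound 4 (0.10 log units; within the scatter). Set beside the earlier step, the two cores show no difference that this measurement can resolve: the same change on two cores in this assay, a 1.2-fold higher number (0.09 log units; within the scatter) from compound 1 to compound 2 and a 1.3-fold lower number (0.10 log units; within the scatter) from compound 3 to compound 4, 1.6-fold (0.19 log units) apart, within the scatter of two such steps. The change from methoxy to hydroxy therefore carries across these two cores without a readable shift in growth inhibition, but with both steps inside the scatter, the pairs do not show that it helps or harms on either core, nor that the opposite signs of the two steps are real, and two pairs cannot speak for the series beyond them.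

The compounds shown leave open whether a different group at this place on the oxygen-bearing carbon, such as an amine or a carboxylic acid, would move the number beyond the scatter. They also leave open whether the same change would behave alike on a core carrying a nitrile in place of trifluoromethyl.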